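Pyrrolidine amide in place of a hexyloxy ester

A few compounds are considered here, and "the series" means these few. Any claim that something is new, unique, unknown or untested is made for them only; others in the source may bear on it.

Compound 1, `CCOc1ccc(-c2cccc(C)c2)cc1`: 70000 nM
Compound 2, `CCCCCCOC(=O)c1cccc(-c2ccc(OCC)cc2)c1`: > 200000 nM

Both compounds share the same core and were tested in an assay on COS-7 cells for inhibition of patatin-like phospholipase domain-containing protein 2 (Mus musculus); a lower number here means a stronger inhibitor, a higher number a weaker inhibitor. Compound 1 gives 70000 nM, a weak inhibition. For compound 2 the read-out is only a limit, > 200000 nM, and not a number. Within the data shown here, this is the limit of > 200000 nM in this assay, at which 1 of the 2 values shown sits, so compound 2 stands at the weak end of what the assay can report, with no measured step between it and compound 1.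

Compound 3, `CCOc1ccc(-c2cccc(C(=O)N3CCCC3)c2)cc1`, has not been measured. It differs from compound 2 in one place: pyrrolidin-1-yl in place of hexyloxy on a carbonyl carbon. Among the measured compounds shown here, no measured pair shows the effect of such a change, so the expectation rests on the two values alone. Compound 3 is expected to give 50000 nM, with a likely range from 10000 nM to 200000 nM. The expected step of an at least 4.0-fold lower number from compound 2 to compound 3 (0.60 log units; beyond the scatter) would be toward stronger inhibition, beyond the usual scatter.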

Compound 3, half-maximal inhibitory concentration: 160000 nM
Beside the measured number, compound 3's estimate is 3.2-fold (0.51 log units) below it; the measured number falls inside the stated range.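

In this assay, among these compounds, placing (pyrrolidin-1-yl)carbonyl in place of methyl on an aromatic carbon gives a 2.3-fold higher number from compound 1 to compound 3 (0.36 log units; beyond the scatter), a modest move toward weaker inhibition and the first measured number for a compound with a carbonyl group at this position. Putting pyrrolidin-1-yl in place of hexyloxy on the carbonyl carbon gives an at least 1.2-fold lower number from compound 2 to compound 3 (0.09 log units; that floor lies within the scatter), so this change is not shown to strengthen inhibition. Compound 2 has only a limit and not a number: the limit of > 200000 nM in this assay, at which 1 of the 3 values shown sits.

On these data alone, the true size of the change from hexyloxy to pyrrolidin-1-yl stays open, with only its floor known. Also open, as far as these compounds go, is whether a carboxylic acid or an open-chain diethylamide on that same aromatic carbon would give a lower number than the methyl group of compound 1.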